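Aryl replacement at the shared core: compound 3

The source may report more compounds than this note shows. Statements on the series, on what has been measured and on what is new or still open speak of the compounds shown alone.

Measured so far in a functional assay on A549 cells (Homo sapiens) for cytotoxicity, read by MTT assay, with a stated time of 24 h; on this read-out lower numbers stand for stronger inhibition and higher numbers for weaker inhibition:
compound 1 `Clc1cccc(-c2nnc(C(NCc3ccccc3)c3ccc[nH]3)o2)c1` — 62200 nM
compound 2 `Clc1ccc(-c2nnc(C(NCc3ccccc3)c3ccc[nH]3)o2)cc1Cl` — 25500 nM
compound 3 `COc1ccc(-c2nnc(C(NCc3ccccc3)c3ccc[nH]3)o2)cc1` — not yet measured

Going by the values given here, compound 1 gives the highest of the two numbers so far; its nearest neighbour is compound 2, and the step of a 2.4-fold lower number from compound 1 to compound 2 (0.39 log units; beyond the scatter) is the only one measured. Compound 3 differs from compound 1 as follows: 4-methoxyphenyl in place of 3-chlorophenyl on an aromatic carbon. Among the compounds with values here, no measured step bears directly on this change: the one available step concerns a chloro added to the 3-chlorophenyl ring, whereas here the 3-chlorophenyl leaves altogether and a 4-methoxyphenyl enters in its place. The step from compound 1 to compound 2 shows only that adding a second chloro produced a modest lowering; it offers no guide to removing the chloro and bringing in a methoxy. The expectation for compound 3 is therefore a number close to that of compound 1, with no step beyond the scatter in either direction, the estimated step being a 1.1-fold higher number from compound 1 to compound 3 (0.05 log units; within the scatter). In this assay compound 3 is estimated at 70000 nM, with a range from 25000 nM to 200000 nM.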

Compound 3, half-maximal inhibitory concentration: 327000 nM
Compound 3: middle estimate off by 4.7-fold (0.67 log units), on the low side; measured number above the stated range.
By their numbers in this assay, from the lowest: compound 2; then compound 1; then compound 3.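

In this assay, the aryl group on the aromatic carbon of the shared core can move the number upward as well as downward: where the earlier pair showed only a modest lowering with an added chloro, 4-methoxyphenyl in place of 3-chlorophenyl gives a 5.3-fold higher number from compound 1 to compound 3 (0.72 log units; beyond the scatter). The same entry of 4-methoxyphenyl, this time in place of 3,4-dichlorophenyl, gives a 13-fold higher number from compound 2 to compound 3 (1.11 log units; beyond the scatter), the one large step among these compounds, and within this set of three, both chlorine-bearing aryl groups give lower numbers than the methoxy-bearing one, with no compound going against that. No measurement at hand accounts for these steps.

The change from 3-chlorophenyl to 4-methoxyphenyl alters both the substituent and its place on the aryl ring, and the compounds shown do not separate the two. Going by these compounds, how the number responds to an unsubstituted phenyl, or to an amine or a carboxylic acid on that ring, also remains open.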